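Compound 3 to compound 4: one ring group exchanged

The source may hold more compounds than are shown below. What is called first, only, known or untested is meant among the compounds shown, and "the series" means these compounds.

Measured in an ADME assay on HEK293 cells (Homo sapiens) for cytotoxicity; on this read-out higher numbers stand for weaker inhibition and lower numbers for stronger inhibition:
- compound 1 `CCCCCCCCCCCCCCNC(=O)[C@H](CO)/N=C/c1cccc([N+](=O)[O-])c1`: 82700 nM
- compound 2 `CCCCCCCCCCCCCCNC(=O)[C@H](CO)/N=C/c1ccc(O)cc1`: 71700 nM
- compound 3 `CCCCCCCCCCCCCCNC(=O)[C@H](CO)/N=C/c1cccc(Cl)c1`: 77000 nM

Compound 3 stands within the scatter of the other two measured compounds. The steps to it are a 1.1-fold higher number from compound 2 to compound 3 (0.03 log units; within the scatter) and a 1.1-fold lower number from compound 1 to compound 3 (0.03 log units; within the scatter). Compound 4 `CCCCCCCCCCCCCCNC(=O)[C@H](CO)/N=C/c1ccccc1C` differs from it in one place: 2-methylphenyl in place of 3-chlorophenyl on a carbon with a double bond to nitrogen. The closest evidence is from exchanges of the ring group at this same place, a 1.2-fold lower number from compound 1 to compound 2 (0.06 log units; within the scatter) and the two steps above, and all of them stayed within the scatter. For the measured compounds named here, no measured compound carries 2-methylphenyl, so that group itself is untested. No step beyond the scatter is therefore expected in this assay, in either direction. The estimated step is a 1.0-fold lower number from compound 3 to compound 4 (0.01 log units; within the scatter). For compound 4 the estimated value is 75000 nM, with an expected range of 45000 nM to 120000 nM.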

Compound 4, half-maximal inhibitory concentration: 81100 nM
The estimate for compound 4 lay 1.1-fold (0.03 log units) below the measured number, within the range that was stated.
By their numbers in this assay, from the lowest: compounds 2, 3, 4 and 1 (each within the scatter of the next).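

In this assay there is a 1.1-fold higher number from compound 3 to compound 4 (0.02 log units; within the scatter) and a 1.1-fold higher number from compound 2 to compound 4 (0.05 log units; within the scatter) and also a 1.0-fold lower number from compound 1 to compound 4 (0.01 log units; within the scatter) so 2-methylphenyl on a carbon with a double bond to nitrogen stays within the scatter of all three earlier ring groups. For the compounds shown here, this extends the flat picture at this position to a ring group with a methyl substituent, a kind absent from the earlier compounds. Going by these compounds, whether an amine or a carboxylic acid on the ring would shift the number stays open, as does the effect of a shorter chain in place of the long one. Nothing available offers an explanation for this result.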